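The source may report more compounds than this note shows. Statements on the series, on what has been measured and on what is new or still open speak of the compounds shown alone.

In an ADME assay on PBMC cells (Homo sapiens) for cytotoxicity, with a stated time of 5 days (a lower number here means a stronger inhibitor, a higher number a weaker inhibitor), compound 3 `Cc1ccc(C2=NNC(c3ccc(N4CCCCC4)cc3)C2)s1` gives 86400 nM, the higher of the two numbers that this series has produced so far. Its nearest neighbour is compound 1 `c1csc(C2=NNC(c3ccc(N4CCCCC4)cc3)C2)c1`, which in this assay gives 20800 nM; the step between them is a 4.2-fold higher number from compound 1 to compound 3 (0.62 log units; beyond the scatter). Compound 2 `c1cc(C2=NNC(c3ccc(N4CCCCC4)cc3)C2)cs1` is reported only as a limit, > 100000 nM in this assay, and that value sits at the limit of > 100000 nM in this assay, at which 1 of the 3 values shown sits. The step of an at least 4.8-fold higher number from compound 1 to compound 2 (0.68 log units; beyond the scatter) is therefore a floor rather than a measured size, and the step of an at least 1.1-fold lower number from compound 2 to compound 3 (0.06 log units; that floor lies within the scatter) says little.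

Compound 4 `Clc1ccsc1C1=NNC(c2ccc(N3CCCCC3)cc2)C1` differs from compound 3 in one place: 3-chlorothiophen-2-yl in place of 5-methylthiophen-2-yl on a carbon with a double bond to nitrogen. Among the measured compounds shown here, two measured steps bear on it. The step of a 4.2-fold higher number from compound 1 to compound 3 (0.62 log units; beyond the scatter) shows that a methyl on this ring raised the number, and that methyl now leaves. For the measured compounds named here, the step of an at least 4.8-fold higher number from compound 1 to compound 2 (0.68 log units; beyond the scatter) shows that the point of attachment of the ring matters, but the chlorine here is a new change for which no step exists. Compound 4 is therefore expected to give roughly 40000 nM, with a range from 15000 nM to 100000 nM. That expectation amounts to a step of a 2.2-fold lower number from compound 3 to compound 4 (0.33 log units; beyond the scatter).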

Compound 4, half-maximal inhibitory concentration: 34200 nM
Compound 4: middle estimate off by 1.2-fold (0.07 log units), on the high side, and the stated range covers the measured number.
By their numbers in this assay, from the lowest: compounds 1 and 4 (each within the scatter of the next); then compound 3. At a limit, above all of these: compound 2.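

Chloro in place of hydrogen on this ring gives a 1.6-fold higher number from compound 1 to compound 4 (0.22 log units; within the scatter), so in this assay the 3-chlorothiophen-2-yl group cannot be told apart from the unsubstituted thiophen-2-yl group. The exchange of 5-methylthiophen-2-yl for 3-chlorothiophen-2-yl gives a 2.5-fold lower number from compound 3 to compound 4 (0.40 log units; beyond the scatter), which shows that a substituted ring at this position does not always bring the higher number seen with the methyl group. The step of an at least 2.9-fold lower number from compound 2 to compound 4 (0.46 log units; beyond the scatter) is a floor, not a measured size: the limit of > 100000 nM in this assay, at which 1 of the 4 values shown sits.

The compounds shown leave open whether the group itself or its place on the ring sets this difference, and how 3-methylthiophen-2-yl or 5-chlorothiophen-2-yl would compare. On these data alone, how an amine or a carboxylic acid on this ring would read in this assay also remains open.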